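Hydrogen in place of acetyl on the shared core

The source may report more compounds than this note shows. Statements on the series, on what has been measured and on what is new or still open speak of the compounds shown alone.

Measured compounds:
compound 1, `COc1ccc(C(=O)O[C@H]2CC(C)=C[C@H](OC(C)=O)[C@@]3(C)[C@@H](OC(C)=O)C[C@@](O)(C(C)C)[C@H]23)cc1`: 11300 nM
compound 2, `COc1ccc(C(=O)O[C@H]2CC(C)=CC[C@@]3(C)CC[C@@](O)(C(C)C)[C@H]23)cc1`: 20100 nM

In a functional assay on HL-60 cells (Homo sapiens) for cytotoxicity, read by MTT assay, with a stated time of 72 h (a higher number here means a weaker inhibitor, a lower number a stronger inhibitor), compound 1 gives 11300 nM, the lower of the two numbers recorded. Lacking the two acetoxy groups of compound 1, compound 2 gives 20100 nM, and the gap between the two lies within the usual scatter, so no order between them can be claimed.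

Compound 3, `COc1ccc(C(=O)O[C@H]2CC(C)=C[C@H](O)[C@@]3(C)[C@@H](OC(C)=O)C[C@@](O)(C(C)C)[C@H]23)cc1`, has not been measured. It differs from compound 1 in one place: hydrogen in place of acetyl on an oxygen on a saturated carbon. Within the data shown here, no step between measured compounds isolates this change, and the only other measured compound, compound 2, sits within the scatter of compound 1.

With so little to go on, the step from compound 1 to compound 3 is expected to be small, a 1.1-fold higher number from compound 1 to compound 3 (0.03 log units; within the scatter), none beyond the scatter in either direction. Compound 3 is therefore estimated at about 12000 nM, with a range from 4000 nM to 40000 nM.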

Compound 3, half-maximal inhibitory concentration: 23000 nM
Beside the measured number, compound 3's estimate is 1.9-fold (0.28 log units) below it; the measured number falls inside the stated range.
By their numbers in this assay, from the lowest: compounds 1, 2 and 3 (each within the scatter of the next, the first and the last beyond it).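

Hydroxy in place of acetoxy on this oxygen gives the first step on the shared core that isolates a single change: in this assay it gives a 2.0-fold higher number from compound 1 to compound 3 (0.31 log units; beyond the scatter), a modest step just beyond the usual scatter. It shows that the acetyl on this oxygen counts for something in this cell read-out, though removing it shifts the number only modestly and does not abolish the cytotoxicity. Nothing available accounts for the direction or size of this step.

The compounds shown leave open whether a methyl ether or a longer ester such as a butyrate on this oxygen would read like compound 1 or like compound 3. Among these compounds, they also leave the contribution of the other acetoxy group on its own unresolved, as no step isolates it.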